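The source may hold more compounds than are shown below. What is called first, only, known or untested is meant among the compounds shown, and "the series" means these compounds.

- compound 1 `COc1ccc(-n2nc(C(=O)N3CCOCC3)cc2-c2ccc(Cl)cc2)cc1`: 7.3 nM
- compound 2 `COc1ccc(-n2nc(C(=O)N3CCCC3)cc2-c2ccc(Cl)cc2)nn1`: 15 nM

In a functional assay on a cell-free system (Platelet, plasma, Homo sapiens) for inhibition, read by turbidimetry, with a stated time of 3 min (on this read-out lower numbers stand for stronger inhibition and higher numbers for weaker inhibition), compound 2 gives 15 nM, the higher of the two numbers and so the weaker inhibition. Compound 1 gives 7.3 nM, and this gap lies beyond the usual scatter. Those two compounds differ in more than one place, so the gap cannot be assigned to a single change.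

Compound 3 `COc1ccc(-n2nc(C(=O)N3CCCC3)cc2-c2ccc(Cl)cc2)cc1`, not yet measured, keeps the (pyrrolidin-1-yl)carbonyl group of compound 2 and differs from it on an aromatic nitrogen: 4-methoxyphenyl in place of 6-methoxypyridazin-3-yl on an aromatic nitrogen. It has 4-methoxyphenyl in place of 6-methoxypyridazin-3-yl. That 4-methoxyphenyl group is also carried by compound 1, which gives 7.3 nM, so a modest move to a lower number in this assay is expected. The estimated step is a 2.3-fold lower number from compound 2 to compound 3 (0.36 log units; beyond the scatter). For compound 3 the expected value is 6.5 nM, with an estimated range of 2.2 nM to 18 nM.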

Compound 3, half-maximal inhibitory concentration: 5.7 nM
Compound 3: the middle estimate sits 1.1-fold (0.06 log units) above what was measured, and the stated range covers the measured number.
By their numbers in this assay, from the lowest: compounds 3 and 1 (each within the scatter of the next); then compound 2.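

Among the compounds shown here, on the aromatic nitrogen, next to the ring atom that bears a 4-chlorophenyl group, the exchange of 6-methoxypyridazin-3-yl for 4-methoxyphenyl now stands as the only change, and in this assay it gives a 2.6-fold lower number from compound 2 to compound 3 (0.42 log units; beyond the scatter). On the carbonyl carbon, pyrrolidin-1-yl in place of morpholin-4-yl gives a 1.3-fold lower number from compound 1 to compound 3 (0.11 log units; within the scatter), so with 4-methoxyphenyl on the nitrogen these two groups cannot be told apart in this assay. No measurement offered here explains either result.

The compounds shown leave open whether pyrrolidin-1-yl and morpholin-4-yl also read alike with 6-methoxypyridazin-3-yl on the nitrogen. They also leave open how a pyridine ring carrying a methoxy group on the nitrogen, or a piperidin-1-yl or dimethylamino group on the carbonyl carbon, would read.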